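Cyclopentyl for cyclopentylmethyl: notes on compound 4

The compounds below may be only part of what the source reports. "The series", "measured", "known", "first", "only" and "open" are said of these compounds alone.

In a functional assay, read by fluorescence and spectrophotometry, with a stated time of 1 h (on this read-out lower numbers stand for an effect already at smaller amounts and higher numbers for an effect only at larger amounts of compound), compound 1 (`O=S(=O)(/C=C/c1ccc(O)c(O)c1)CC1CC1`) reads 10500 nM and compound 2 (`CCCCCCS(=O)(=O)/C=C/c1ccc(O)c(O)c1`) reads 7300 nM while compound 3 (`O=S(=O)(/C=C/c1ccc(O)c(O)c1)CCC1CCCC1`) reads 6800 nM and so stands level with both within the scatter.

Compound 4 (`O=S(=O)(/C=C/c1ccc(O)c(O)c1)CC1CCCC1`) carries cyclopentyl in place of cyclopentylmethyl on a saturated chain carbon bound to a sulfonyl sulfur. Among the measured compounds shown here, no measured step makes this exact change, and cyclopentyl itself has not been measured at this place.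

For the measured compounds named here, three measured steps bear on it: a 1.5-fold lower number from compound 1 to compound 3 (0.19 log units; within the scatter) and a 1.4-fold lower number from compound 1 to compound 2 (0.16 log units; within the scatter) on the same saturated chain carbon, and a 1.1-fold lower number from compound 2 to compound 3 (0.03 log units; within the scatter) two bonds along the chain from the sulfonyl sulfur. All three lie within the scatter, so no step beyond the scatter is expected in this assay and no firm direction can be drawn from them. The estimated step is a 1.2-fold higher number from compound 3 to compound 4 (0.07 log units; within the scatter) and is expected to stay within the scatter. Compound 4 is estimated at 8000 nM (4500 nM to 14000 nM).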

Compound 4, half-maximal effective concentration: 9400 nM
For compound 4 the middle estimate is 1.2-fold (0.07 log units) below the measured one; low and high end bracket the measured number.
By their numbers in this assay, from the lowest: compounds 3, 2, 4 and 1 (each within the scatter of the next).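

In this assay cyclopentyl in place of cyclopentylmethyl gives a 1.4-fold higher number from compound 3 to compound 4 (0.14 log units; within the scatter) and stays within the scatter, so removing the one carbon between the ring and the saturated chain carbon bound to a sulfonyl sulfur brings no readable change. Cyclopentyl in place of pentyl gives a 1.3-fold higher number from compound 2 to compound 4 (0.11 log units; within the scatter) and cyclopentyl in place of cyclopropyl gives a 1.1-fold lower number from compound 1 to compound 4 (0.05 log units; within the scatter) and both also stay within the scatter, so all four carbon-only groups now stand level at this place. Nothing on hand gives a reason for this flat picture.

Going by these compounds, whether any group at this place can move the number beyond the scatter stays open, for instance an amine, a carboxylic acid or a longer chain such as decyl. On these data alone, what a change on the shared core would do also stays open, as all four compounds carry it unchanged.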